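The source may report more compounds than this note shows. Statements on the series, on what has been measured and on what is new or still open speak of the compounds shown alone.

Compound 2 `Cc1ccc(-c2nc(N)c3cc(Cc4ccccc4Cl)sc3n2)o1` is one of three close analogues measured in a functional assay on CHO-K1 cells for antagonist activity at adenosine receptor A1 (Homo sapiens), read by a beta-galactosidase reporter and cAMP accumulation, with stated times of 15 min and 6 h (a lower number here means a stronger inhibitor, a higher number a weaker inhibitor), where compound 2 gives 26.1 nM. Compound 1 `Cc1ccc(-c2nc(N)c3cc(CCc4ccccc4)sc3n2)o1` gives 2780 nM in this assay, and the step of a 110-fold lower number from compound 1 to compound 2 (2.03 log units; beyond the scatter) is large. Compound 3 `Cc1ccc(-c2nc(N)c3cc(Cc4ccccc4F)sc3n2)o1` reaches only a limit of this assay, < 16 nM. Of the two plain numbers, compound 2 holds the lower one; the step of an at least 1.6-fold lower number from compound 2 to compound 3 (0.21 log units; that floor lies within the scatter) is bounded by a floor that stays within the scatter. Compound 4 `Cc1csc(-c2nc(N)c3cc(Cc4ccccc4Cl)sc3n2)n1` differs from compound 2 by 4-methyl-1,3-thiazol-2-yl in place of 5-methylfuran-2-yl on an aromatic carbon. Going by the values given here, no measured step touches this part of the shared core; the steps of a 110-fold lower number from compound 1 to compound 2 (2.03 log units; beyond the scatter) and an at least 170-fold lower number from compound 1 to compound 3 (2.23 log units; beyond the scatter) concern the benzyl side only, so they bear on this change loosely. Compound 4 is therefore expected to stay near compound 2, with an estimated step of a 1.5-fold higher number from compound 2 to compound 4 (0.19 log units; within the scatter) not beyond the scatter. The estimate for compound 4 is 40 nM, between 10 nM and 160 nM.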

Compound 4, inhibition constant: 49.6 nM
Estimate against measurement, compound 4: 1.2-fold (0.09 log units) below; the measured number falls inside the stated range.
By their numbers in this assay, from the lowest: compounds 2 and 4 (each within the scatter of the next); then compound 1. At a limit, below all of these: compound 3.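

Going by these compounds alone, this is the first change at the position between two ring nitrogen atoms, since compounds 1, 2 and 3 all carry 5-methylfuran-2-yl and differ only on the other side of the shared core. In this assay, replacing that ring with 4-methyl-1,3-thiazol-2-yl gives a 1.9-fold higher number from compound 2 to compound 4 (0.28 log units; within the scatter), so this position accepts either five-membered ring without a clear change. Nothing shown accounts for this result.

As far as these compounds go, whether a plain phenyl ring or a morpholine would also be accepted here remains open. So does whether 4-methyl-1,3-thiazol-2-yl behaves the same alongside the other side groups.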